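The source may report more compounds than this note shows. Statements on the series, on what has been measured and on what is new or still open speak of the compounds shown alone.

Compound 2 `CCN(CC)c1cc2[nH]c(-c3ccccc3OC)nc2cc1NC(=O)C1CCC1` stands at the assay's ceiling: in an ADME assay on Vero cells (Chlorocebus sabaeus) for cytotoxicity, with a stated time of 3 days (a lower number here means a stronger inhibitor, a higher number a weaker inhibitor), compound 2 gives > 200 ug/mL, a limit rather than a number. Compound 1 `CCN(CC)c1cc2[nH]c(-c3ccc(F)cc3)nc2cc1NC(=O)C1CCC1` likewise gives only a limit, > 200 ug/mL. Compound 3 `CCN(CC)c1cc2[nH]c(-c3ccc(C)cc3)nc2cc1NC(=O)C1CCC1` also gives only a limit, > 200 ug/mL. All three values sit at the limit of > 200 ug/mL in this assay, at which 3 of the 3 values shown sit, so the steps a step that the two limits leave unreadable from compound 1 to compound 2, a step that the two limits leave unreadable from compound 1 to compound 3 and a step that the two limits leave unreadable from compound 2 to compound 3 cannot be read in size or direction. Compound 4 `CCN(CC)c1cc2[nH]c(-c3ccccc3OC)nc2cc1NC(=O)c1ccccc1OC` differs from compound 2 by 2-methoxyphenyl in place of cyclobutyl on a carbonyl carbon. Among the compounds with values here, none of the measured steps touches the amide side of the core, and none has a readable size, so in this assay no shift beyond scatter is expected. Compound 4 is expected at 200 ug/mL, within 100 ug/mL to 400 ug/mL, most probably again as a limit. The estimated step is a number no higher from compound 2 to compound 4 (the limit leaves the size open).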

Compound 4, half-maximal inhibitory concentration: > 200 ug/mL
Compound 4: a limit, no number; the forecaster's own chance of this, stated with the estimate: 75%; the middle value sits exactly at the limit.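

The step between compound 2 and compound 4 cannot be read, because both give only a limit: the limit of > 200 ug/mL in this assay, at which 4 of the 4 values shown sit.

The compounds shown leave open whether any of these groups changes the read-out in this assay at all.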